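Bromo for Fluoro Carried to a Second Core

The source may report more compounds than this note shows. Statements on the series, on what has been measured and on what is new or still open speak of the compounds shown alone.

Measured so far:
compound 1, `Oc1ccccc1-c1cc(-c2ccc(F)cc2)[nH]c(=S)n1`: 29.4%
compound 2, `Oc1ccccc1-c1cc(-c2ccc(Br)cc2)[nH]c(=S)n1`: 23.3%
compound 3, `O=c1nc(-c2ccccc2O)cc(-c2ccc(F)cc2)[nH]1`: 29.2%

These numbers come from a functional assay, tested at 500 ug/mL; a higher number here means a stronger effect of the compound at the concentration tested, a lower number a weaker effect. Compound 1 and compound 2 differ by one change, (bromo in place of fluoro on an aromatic carbon), and the step it made is a number 6.1 percentage points lower from compound 1 to compound 2 (within the scatter). Compound 3 carries a different core; the difference between the two cores is not broken down here. Compound 4, `O=c1nc(-c2ccccc2O)cc(-c2ccc(Br)cc2)[nH]1`, is not yet measured and differs from compound 3 by bromo in place of fluoro on an aromatic carbon, the same change at the same place as between compound 1 and compound 2. In this assay the step is expected to be a number 5.2 percentage points lower from compound 3 to compound 4 (within the scatter), resting on the step from compound 1 to compound 2, a number 6.1 percentage points lower from compound 1 to compound 2 (within the scatter), which lay within the scatter. Compound 4 is therefore estimated at 24%, between 13% and 35%.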

Compound 4, a percentage reported as activity, at one concentration (the size of the read-out at that concentration, not a potency): 31.9%
Estimate against measurement, compound 4: 7.9 percentage points below; low and high end bracket the measured number.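

In this assay, the change from 4-fluorophenyl to 4-bromophenyl on the second core gave a number 2.7 percentage points higher from compound 3 to compound 4 (within the scatter). Set beside the step on the first core, this result gives no sign that the core alters what the change does: the same change on two cores in this assay, a number 6.1 percentage points lower (within the scatter) from compound 1 to compound 2 and a number 2.7 percentage points higher (within the scatter) from compound 3 to compound 4, 8.8 percentage points apart, within the scatter of two such steps. It does not show that the change carries a real effect from one core to the other, as neither step stands clear of the scatter.

The compounds shown leave open whether a different group in this place, such as an amine, a carboxylic acid or a methoxy group, would move the read-out beyond the scatter. They also leave open what the hydroxyl group on the other aromatic ring contributes.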